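The compounds below may be only part of what the source reports. "The series", "measured", "known", "first", "only" and "open" are said of these compounds alone.

Working notes on the series. Compound 1 `O=C1O/C(=C\Cn2cc(C3=CCCCC3)nn2)C(OCc2ccccc2)=C1OCc1ccccc1` is tested in a functional assay on U-937 cells (Homo sapiens) for antiproliferative activity, read by MTT assay, with a stated time of 24 h; on this read-out lower numbers stand for stronger inhibition and higher numbers for weaker inhibition. For compound 1 only a limit of the assay is recorded, > 100000 nM, and not a number. Compound 2 `Cc1ccc(-c2cn(CCC3(O)NC(=O)C(OCc4ccccc4)=C3OCc3ccccc3)nn2)cc1` gives 54000 nM in this assay. For compound 3 `CCCc1cn(CCC2(O)C(OCc3ccccc3)=C(OCc3ccccc3)C(=O)N2CCC)nn1` this assay again returns only a limit, > 100000 nM. Compound 1 thus stands at the weak end of the recorded values, together with compound 3, as shown by the limit of > 100000 nM in this assay, at which 2 of the 3 values shown sit. Among the compounds with values here, no step between measured compounds that differ in a single place is recorded, so nothing ties a change on the shared core to a measured shift in this assay.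

Compound 4 `CC(C)(C)c1ccc(-c2cn(C/C=C3\OC(=O)C(OCc4ccccc4)=C3OCc3ccccc3)nn2)cc1` differs from compound 1 in one place: 4-(tert-butyl)phenyl in place of cyclohex-1-en-1-yl on an aromatic carbon. Whether this change moves the read-out beyond the scatter cannot be read from the three recorded values. The expectation is a modest step toward stronger inhibition, an at least 1.6-fold lower number from compound 1 to compound 4 (0.22 log units; that floor lies within the scatter), with a fair chance that this assay returns only a limit again. Compound 4 is estimated at 60000 nM in this assay, with a range from 20000 nM to 150000 nM.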

Compound 4, half-maximal inhibitory concentration: > 100000 nM
Compound 4: only a limit was reported (the forecaster's own chance of this, stated with the estimate: 45%); at least 1.6-fold (0.22 log units) between middle value and limit.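

No step can be read between compound 1 and compound 4, because each carries only a limit in this assay: the limit of > 100000 nM in this assay, at which 3 of the 4 values shown sit.

The compounds shown leave open whether 4-(tert-butyl)phenyl in place of cyclohex-1-en-1-yl on an aromatic carbon shifts inhibition in either direction.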